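Methyl in place of hydrogen on the acid: two cores

The compounds below may be only part of what the source reports. "The series", "measured", "known", "first", "only" and "open" are said of these compounds alone.

Measured so far:
compound 1 `COC(=O)c1cccc(-c2cnc(C(=O)CCc3ccc(OC4CCN(C(=O)OC(C)(C)C)CC4)cc3)o2)n1` gives 32 nM in an assay for inhibition of Fatty-acid amide hydrolase 1 (Rattus norvegicus); on this read-out lower numbers stand for stronger inhibition and higher numbers for weaker inhibition
compound 3 `CC(C)(C)OC(=O)N1CCC(Oc2ccc(CCC(=O)c3ncc(-c4cccc(C(=O)O)n4)o3)cc2)CC1` gives 120 nM in this assay
compound 2 `O=C(O)c1ccc(-c2cnc(CCCc3ccc(-c4ccccc4)cc3)o2)nc1` gives 20000 nM in this assay

Compounds 3 and 1 share one core and differ only by methyl in place of hydrogen on an oxygen next to a carbonyl group; this step gave a 3.8-fold lower number from compound 3 to compound 1 (0.57 log units; beyond the scatter). Compound 2 sits on a different core, and the difference between the two cores is not broken down here; its value stands far from those of compounds 3 and 1.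

Compound 4 `COC(=O)c1ccc(-c2cnc(CCCc3ccc(-c4ccccc4)cc3)o2)nc1` is not yet measured. It differs from compound 2 by methyl in place of hydrogen on an oxygen next to a carbonyl group. The surroundings are not identical word for word: in the first pair the change reads 6-carboxypyridin-2-yl to 6-(methoxycarbonyl)pyridin-2-yl, in the second 5-carboxypyridin-2-yl to 5-(methoxycarbonyl)pyridin-2-yl, so this is the same kind of change rather than the same change. Within the data shown here, with only one earlier example, the expectation for compound 4 is a step of similar, modest size, a 3.3-fold lower number from compound 2 to compound 4 (0.52 log units; beyond the scatter), resting on the step of a 3.8-fold lower number from compound 3 to compound 1 (0.57 log units; beyond the scatter) from compound 3 to compound 1 alone. Compound 4 is therefore estimated at 6000 nM in this assay, within 1500 nM to 20000 nM.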

Compound 4, inhibition constant: 50000 nM
Estimate against measurement, compound 4: 8.3-fold (0.92 log units) below; the measured number lies above the stated range.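

In this assay methyl in place of hydrogen on the oxygen next to the carbonyl group gives a 2.5-fold higher number from compound 2 to compound 4 (0.40 log units; beyond the scatter) and so does not keep the direction it had on the core of compound 3. This shows that the lower number seen on one core cannot be assumed on the other, but two pairs make no rule, and they do not show what sets the steps apart, as the pairs differ both in the rest of the core and in carrying 5-carboxypyridin-2-yl rather than 6-carboxypyridin-2-yl. The two steps disagree in direction and in size: the same change on two cores in this assay, a 3.8-fold lower number (0.57 log units; beyond the scatter) from compound 3 to compound 1 and a 2.5-fold higher number (0.40 log units; beyond the scatter) from compound 2 to compound 4, 9.4-fold (0.97 log units) apart, beyond the scatter of two such steps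

Open, as far as these compounds go, is whether the step follows the place of the acid or the rest of the core, which a matched pair with 5-carboxypyridin-2-yl on the core of compound 3 would separate. Also open, from the compounds shown here alone, is how an ethyl ester or a primary amide in place of methoxycarbonyl would read on either core.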